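A few compounds are considered here, and "the series" means these few. Any claim that something is new, unique, unknown or untested is made for them only; others in the source may bear on it.

In a functional assay on SK-BR-3 cells (Homo sapiens) for antiproliferative activity (on this read-out higher numbers stand for weaker inhibition and lower numbers for stronger inhibition), compound 1 (`C=CCc1cc(C(=O)Nc2cc3ccc(OC4CCN(C)CC4)c(C)c3oc2=O)ccc1OC(C)=O`) gives 2260 nM, compound 2 (`CC(=O)Oc1ccc(C(=O)Nc2cc3ccc(OC4CCN(C)CC4)c(C)c3oc2=O)cc1`) gives 1670 nM and compound 3 (`CC(=O)Oc1ccc(C(=O)Nc2cc3ccc(OC4CCN(C)CC4)c(C)c3oc2=O)cc1Cl`) gives 3500 nM. Compound 3 stands at the upper end of these numbers but clear of compound 2 only: the data show a 2.1-fold higher number from compound 2 to compound 3 (0.32 log units; beyond the scatter), whereas they show a 1.5-fold higher number from compound 1 to compound 3 (0.19 log units; within the scatter). Compound 4 (`COc1cccc(-c2cc(C(=O)Nc3cc4ccc(OC5CCN(C)CC5)c(C)c4oc3=O)ccc2OC(C)=O)c1`) has 3-methoxyphenyl in place of chloro on an aromatic carbon, ortho to an acetoxy group: 3-methoxyphenyl in place of chloro on an aromatic carbon. Among the measured compounds shown here, the same carbon also gives a 1.4-fold lower number from compound 1 to compound 2 (0.13 log units; within the scatter), so all three measured steps there are small, yet no measured compound carries a ring at that carbon and the guide is loose. The expected change is a 1.8-fold lower number from compound 3 to compound 4 (0.24 log units; within the scatter), a shift to a lower number that is not expected to exceed the scatter. For compound 4 the estimate is 2000 nM, with an expected range from 700 nM to 5500 nM.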

Compound 4, half-maximal inhibitory concentration: 920 nM
Compound 4: the middle estimate sits 2.2-fold (0.34 log units) above what was measured; the range from low to high includes it.
By their numbers in this assay, from the lowest: compounds 4, 2, 1 and 3 (each within the scatter of the next, the first and the last beyond it).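

In this assay, among the compounds shown here, a ring at this carbon, ortho to an acetoxy group, gives a 3.8-fold lower number from compound 3 to compound 4 (0.58 log units; beyond the scatter) and a 2.5-fold lower number from compound 1 to compound 4 (0.39 log units; beyond the scatter), the first steps at this position beyond the scatter towards a lower number. Against hydrogen, however, the same ring gives a 1.8-fold lower number from compound 2 to compound 4 (0.26 log units; within the scatter), so it cannot be separated from the compound with no substituent there. Nothing available explains these steps.

Going by these compounds, it remains open whether the methoxy group matters, or whether plain phenyl or a pyridine ring would read the same. A ring bearing an amine or a carboxylic acid is also untested by these compounds.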